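Pyrrole in Place of Thiophene on a Weak Inhibitor

The compounds below may be only part of what the source reports. "The series", "measured", "known", "first", "only" and "open" are said of these compounds alone.

Compound 1, `Nc1nc(-c2ccccc2)cc(-c2cnn(-c3ccccc3)n2)n1`: > 200000 nM
Compound 2, `Nc1nc(-c2ccccc2)cc(-c2cccs2)n1`: 85100 nM

Of the compounds shown here, two have been tested in a functional assay on SNB-19 cells (Homo sapiens) for inhibition, read by MTT assay; a lower number here means a stronger inhibitor, a higher number a weaker inhibitor. Compound 1 reaches only > 200000 nM, which is a limit of the assay and not a number. Compound 2 gives 85100 nM in this assay and thus stands as the only number shown; the other value sits at the limit of > 200000 nM in this assay, at which 1 of the 2 values shown sits. Both compounds share the same core, and compound 2 is a weak inhibitor by this reading.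

Compound 3 `Nc1nc(-c2ccccc2)cc(-c2ccc[nH]2)n1` has not been measured. It differs from compound 2 in one place: 1H-pyrrol-2-yl in place of thiophen-2-yl on an aromatic carbon. Within the data shown here, no step between two measured compounds describes such an exchange, so no measured size can be carried over. In this assay the change from compound 2 to compound 3 is expected to stay within the usual scatter, with no clear direction either way. Compound 3 is therefore estimated at 90000 nM, within a range from 30000 nM to 200000 nM, which means an expected step of a 1.1-fold higher number from compound 2 to compound 3 (0.02 log units; within the scatter).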

Compound 3, half-maximal inhibitory concentration: 174000 nM
For compound 3 the middle estimate is 1.9-fold (0.29 log units) below the measured one; the range from low to high includes it.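

Among these compounds, exchanging thiophen-2-yl for 1H-pyrrol-2-yl on this aromatic carbon of the shared core gives the first readable step at this position (a 2.0-fold higher number from compound 2 to compound 3 (0.31 log units; beyond the scatter)), modest in size but printed as beyond the scatter. The group that leaves and the group that enters are both five-membered aromatic rings with the same count of heavy atoms and a single hetero atom, so the position responds in this assay to a change of sulfur to nitrogen, with a hydrogen-bond acceptor giving way to a hydrogen-bond donor in the counts, and not only to the size of the ring. Among the compounds shown here, compound 1 remains a limit of the assay and not a number, so it gives no step to set beside this one: the limit of > 200000 nM in this assay, at which 1 of the 3 values shown sits.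

The compounds shown leave open how a furan-2-yl ring, with oxygen as its hetero atom, or a 1-methylpyrrol-2-yl group, with no hydrogen on its ring nitrogen, would read here, and so whether the hetero atom or the hydrogen on nitrogen goes with the step. They also leave open whether a pyridin-2-yl ring or an aminomethyl group at this position would lower the number in this assay at all.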